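Fluorines in place of methoxy: expected cytotoxicity of compound 4

The compounds below may be only part of what the source reports. "The series", "measured", "known", "first", "only" and "open" are said of these compounds alone.

Three compounds built on a shared core were examined for how well cells tolerate them. Compound 1 `COC(=O)c1cc(-c2cccc(NC(=O)c3ccc(/C=C/C(=O)c4ccccc4)cc3)c2)on1` was tested in an ADME assay on Vero cells (Chlorocebus sabaeus) for cytotoxicity, read by MTT assay, with a stated time of 72 h; a higher number here means that more compound is tolerated, a lower number that less compound is tolerated; there compound 1 gives > 50 ug/mL, which is a limit of the assay and not a number. Compound 2 `COC(=O)c1cc(-c2cccc(NC(=O)c3ccc(/C=C/C(=O)c4ccccc4OC)cc3)c2)on1` carries a methoxy in place of hydrogen on an aromatic carbon; in this assay compound 2 gives > 40 ug/mL, again only a limit. The step that the two limits leave unreadable from compound 1 to compound 2 is therefore unreadable, since both ends are limits the limit of > 40 ug/mL in this assay, at which 1 of the 3 values shown sits (the limit of > 50 ug/mL in this assay, at which 1 of the 3 values shown sits). Compound 3 `CCOC(=O)c1nnn(-c2cccc(NC(=O)c3ccc(/C=C/C(=O)c4ccc(Cl)cc4)cc3)c2)c1C` has no result in this assay ("not determined" (no result reported)). So compound 2 stands at a limit, one further value is also a limit, and the third entry carries no number at all.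

Compound 4 `COC(=O)c1cc(-c2cccc(NC(=O)c3ccc(/C=C/C(=O)c4ccc(F)cc4F)cc3)c2)on1` differs from compound 2 by 2,4-difluorophenyl in place of 2-methoxyphenyl on a carbonyl carbon. Going by the values given here, no measured step bears directly on this change, and the only step between measured compounds is unreadable. With compound 2 sitting at a limit, the step that the limit leaves unreadable from compound 2 to compound 4 is expected to stay within the scatter. Compound 4 is therefore expected to give 50 ug/mL in this assay, with a likely range from 25 ug/mL to 100 ug/mL, and quite possibly only a limit again.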

Compound 4, half-maximal cytotoxic concentration: > 40 ug/mL
Compound 4 ended at the assay's limit (the forecaster's own chance of this, stated with the estimate: 65%); the middle value is on the limit's open side.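

Compound 1, compound 2 and compound 4 all stand at limits in this assay, not at numbers, so the steps among them cannot be read. The compounds shown leave open how much of each compound the cells actually tolerate, and whether phenyl, 2-methoxyphenyl or 2,4-difluorophenyl on the carbonyl carbon makes any difference.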